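The source may hold more compounds than are shown below. What is called first, only, known or untested is meant among the compounds shown, and "the series" means these compounds.

In a functional assay on DU-145 cells (Homo sapiens) for antiproliferative activity, read by MTT assay, with a stated time of 72 h (a higher number here means a weaker inhibitor, a lower number a stronger inhibitor), compound 1 `Cc1cccc(C)c1-c1cc(-c2ccc(/C=C/C(=O)O)cc2Cl)ccc1O` is reported at > 10000 nM, which is a limit of the assay and not a number. Compound 2 `CC1(c2cc(-c3ccc(/C=C/C(=O)O)cc3Cl)ccc2O)SCCCS1` is reported at > 20000 nM, and this too is a limit rather than a number. Among the compounds with values here, compound 2 therefore has no exact potency in this assay, and the only other value shown is also a limit.

Compound 3 `CCC(CC)(CC)c1cc(-c2ccc(/C=C/C(=O)O)cc2Cl)ccc1O` carries a 1,1-diethylpropyl group in place of the sulfur-containing ring of compound 2, on an aromatic carbon ortho to a hydroxy group and meta to a large group: a group of 7 heavy atoms (7 carbon; no ring) in place of a group of 7 heavy atoms (5 carbon, 2 sulfur; one six-membered non-aromatic ring with 2 hetero atoms), on an aromatic carbon. Within the data shown here, one measured step bears on this change, and it is a step that the two limits leave unreadable from compound 1 to compound 2. That step gives no size to carry forward, so the data support no expectation of a clear gain or loss. Compound 3 is expected to stay weak in this assay, and it may also return only a limit. The expected change is an at least 1.6-fold lower number from compound 2 to compound 3 (0.22 log units; that floor lies within the scatter). Compound 3 is estimated at 12000 nM, with an expected range from 3000 nM to 30000 nM.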

Compound 3, half-maximal inhibitory concentration: > 5000 nM
Compound 3 was reported as a limit (the forecaster's own chance of this, stated with the estimate: 55%); the middle value does not contradict the limit.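

In this assay, within the data shown here, compound 1, compound 2 and compound 3 are each reported only as a limit and not as a number, so no step among them can be read. The compounds shown leave open whether 1,1-diethylpropyl, 2,6-dimethylphenyl and the sulfur-containing ring differ at all in this assay on the shared core.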